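Methyl to trifluoromethyl on the amide of compound 3

The source may report more compounds than this note shows. Statements on the series, on what has been measured and on what is new or still open speak of the compounds shown alone.

Measured so far:
compound 1 `Cc1ccc(S(=O)(=O)N(Cc2cccc(F)c2F)Cc2cn(S(=O)(=O)c3ccc(F)cc3)c3ccccc23)cc1`: -35%
compound 2 `O=S(=O)(c1ccc(F)cc1)n1cc(CNCc2cccc(F)c2F)c2ccccc21`: 21%
compound 3 `CC(=O)N(Cc1cn(Cc2cccc(F)c2F)nn1)Cc1cn(S(=O)(=O)c2ccc(C)cc2)c2ccccc12`: 39.5%

In a functional assay on 3T3-L1 cells (Mus musculus) for inhibition, with a stated time of 20 min, tested at 20 uM (on this read-out lower numbers stand for less inhibition and higher numbers for more inhibition at the one concentration tested (going by the name of the read-out)), compound 3 gives the highest number of the three, with compound 2 next and compound 1 lowest, both gaps beyond the scatter. Among the compounds with values here, the single measured step, a number 56 percentage points higher from compound 1 to compound 2 (beyond the scatter), concerns a sulfonyl group on an amine nitrogen and says nothing about the acetyl carbonyl. Compound 4 `Cc1ccc(S(=O)(=O)n2cc(CN(Cc3cn(Cc4cccc(F)c4F)nn3)C(=O)C(F)(F)F)c3ccccc32)cc1` differs from compound 3 by trifluoromethyl in place of methyl on a carbonyl carbon. Within the data shown here, no measured pair bears on this change, so a step no larger than the scatter is expected in this assay: a number 1.5 percentage points lower from compound 3 to compound 4 (within the scatter). Compound 4 is therefore estimated at 38% in this assay, with a range from 15% to 60%.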

Compound 4, a percentage reported as inhibition, at one concentration (the size of the read-out at that concentration, not a potency): 31.9%
Estimate against measurement, compound 4: 6.1 percentage points above; the range from low to high includes it.
By their numbers in this assay, from the lowest: compound 1; then compound 2; then compounds 4 and 3 (each within the scatter of the next).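

In this assay trifluoromethyl in place of methyl on the carbonyl carbon does not separate the two compounds (a number 7.6 percentage points lower from compound 3 to compound 4 (within the scatter)), so this position accepts the larger group without a change that can be read. Within the data shown here, this is the only step that bears on the amide, as the earlier step concerned a sulfonyl group on an amine nitrogen. Nothing available explains the result.

On these data alone, whether a longer chain or an amine on this carbonyl carbon would move the number beyond the scatter remains open.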